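Swapping One Aryl Group for Another on the Amide Nitrogen

This account rests on a few compounds, and the source may have more. Where it says the series, first, only, none or still open, it means among the compounds named here.

Measured so far:
Compound 1 `COc1ccc(CNC(=O)/C=C/c2coc3cc(OC)ccc3c2=O)cc1`: 15700 nM
Compound 2 `CCOc1ccc(NC(=O)/C=C/c2coc3cc(OC)ccc3c2=O)cc1`: a limit of the assay, > 100000 nM
Compound 3 `COc1ccc2c(=O)c(/C=C/C(=O)Nc3cccc(C)c3)coc2c1`: a limit of the assay, > 100000 nM

The three compounds share one core and differ only in the group on the amide-type nitrogen. In a functional assay (QGY7701 cells, Homo sapiens) for inhibition, read by MTT assay, with a stated time of 48 h (on this read-out higher numbers stand for weaker inhibition and lower numbers for stronger inhibition), compound 1, carrying a 4-methoxybenzyl group, gives 15700 nM. Compound 2, with a 4-ethoxyphenyl group, reaches only a limit of the assay, > 100000 nM. Compound 3, with a 3-methylphenyl group, likewise gives only a limit, > 100000 nM. Compound 3 thus stands at the weak end of what has been seen, without a number to place it more exactly.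

The two readable steps point the same way: an at least 6.3-fold higher number from compound 1 to compound 2 (0.80 log units; beyond the scatter) and an at least 6.3-fold higher number from compound 1 to compound 3 (0.80 log units; beyond the scatter). The step that the two limits leave unreadable from compound 2 to compound 3 cannot be read because of the limit of > 100000 nM in this assay, at which 2 of the 3 values shown sit.

Compound 4 `COc1ccc2c(=O)c(/C=C/C(=O)Nc3ccccc3Cl)coc2c1` is the next member: 2-chlorophenyl in place of 3-methylphenyl on an amide-type nitrogen. Going by the values given here, the one step that bears directly on it, between two aryl groups on this nitrogen, is unreadable, and both aryl compounds sit at the limit. The expectation for compound 4 is therefore another limit rather than a number, with an estimated step that the limit leaves unreadable from compound 3 to compound 4. Compound 4 is estimated at 150000 nM, within 40000 nM to 600000 nM.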

Compound 4, half-maximal inhibitory concentration: 23000 nM
Estimate against measurement, compound 4: 6.5-fold (0.81 log units) above; the whole stated range lies above it.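

Going by these compounds alone, until this result, both compounds with an aryl group directly on the amide-type nitrogen sat at a limit, so an aryl group there might have seemed to end measurable activity, and the 2-chlorophenyl group shows that it need not. In this assay, 2-chlorophenyl in place of 3-methylphenyl gives an at least 4.3-fold lower number from compound 3 to compound 4 (0.63 log units; beyond the scatter), and 2-chlorophenyl in place of 4-ethoxyphenyl gives an at least 4.3-fold lower number from compound 2 to compound 4 (0.63 log units; beyond the scatter). The choice of aryl group therefore matters at this position, and the simple contrast between a benzyl group and an aryl group does not hold, since 2-chlorophenyl cannot be told apart from 4-methoxybenzyl here: a 1.5-fold higher number from compound 1 to compound 4 (0.17 log units; within the scatter).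

The compounds shown do not separate the effect of the chlorine from the effect of where it sits on the ring, and a plain phenyl group or a bromine in place of the chlorine would be needed to begin telling these apart. The true sizes of the steps from compound 2 and compound 3 stay unknown, and those two compounds cannot be ranked against each other, for one reason: the limit of > 100000 nM in this assay, at which 2 of the 4 values shown sit.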